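The source may hold more compounds than are shown below. What is called first, only, known or untested is meant among the compounds shown, and "the series" means these compounds.

Compound 1 `COc1cc(-c2nn(-c3cccc(NC(=O)c4cccc(C(F)(F)F)c4)c3)cc2-c2ccncc2)ccc1Cl`: 1200 nM
Compound 2 `COc1cc(-c2nn(-c3cccc(NC(=O)Nc4cccc(C(F)(F)F)c4)c3)cc2-c2ccncc2)ccc1Cl`: 580 nM
Compound 3 `COc1cc(-c2nn(-c3cccc(NC(=O)c4ccc(Cl)c(C(F)(F)F)c4)c3)cc2-c2ccncc2)ccc1Cl`: 2420 nM

In a functional assay on OVCAR-3 cells (Homo sapiens) for inhibition, read by sulforhodamine B assay, with a stated time of 48 h (a lower number here means a stronger inhibitor, a higher number a weaker inhibitor), compound 3 gives the highest of the three numbers. Its nearest neighbour is reached by a 2.0-fold higher number from compound 1 to compound 3 (0.30 log units; within the scatter), and the widest gap is a 4.2-fold higher number from compound 2 to compound 3 (0.62 log units; beyond the scatter). Compound 4 `COc1cc(-c2nn(-c3cccc(NC(=O)Nc4ccc(Cl)c(C(F)(F)F)c4)c3)cc2-c2ccncc2)ccc1Cl` differs from compound 3 in one place: (4-chloro-3-(trifluoromethyl)phenyl)amino in place of 4-chloro-3-(trifluoromethyl)phenyl on a carbonyl carbon. The same kind of change, a carbonyl-linked aryl turned into the corresponding arylamino on the carbonyl carbon, has been measured once already in this set, as a 2.1-fold lower number from compound 1 to compound 2 (0.32 log units; beyond the scatter), a step beyond the scatter toward a lower number. Among the compounds with values here, no other measured step bears directly on it. By analogy, the step from compound 3 to compound 4 in this assay is expected to be of similar size and in the same direction, a lower number, and is estimated as a 2.1-fold lower number from compound 3 to compound 4 (0.32 log units; beyond the scatter). Compound 4 is therefore expected to give about 1150 nM, with a range from 500 nM to 2600 nM.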

Compound 4, half-maximal inhibitory concentration: 890 nM
Compound 4: middle estimate off by 1.3-fold (0.11 log units), on the high side; low and high end bracket the measured number.
By their numbers in this assay, from the lowest: compounds 2, 4, 1 and 3 (each within the scatter of the next, the first and the last beyond it).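

In this assay the exchange of an aryl group for the matching arylamino group on the carbonyl carbon now gives a lower number on a second pair, a 2.7-fold lower number from compound 3 to compound 4 (0.43 log units; beyond the scatter), so the earlier step no longer stands alone. Chloro in place of hydrogen on an aromatic carbon, seen before only with the aryl group on the carbonyl carbon, now also stays within the scatter with the arylamino group, a 1.5-fold higher number from compound 2 to compound 4 (0.19 log units; within the scatter), and the two readings agree: the same change on two cores in this assay, a 2.0-fold higher number (0.30 log units; within the scatter) from compound 1 to compound 3 and a 1.5-fold higher number (0.19 log units; within the scatter) from compound 2 to compound 4, 1.3-fold (0.12 log units) apart, within the scatter of two such steps. With both changes present, the pair of compounds that differ by the whole exchanged group also stays within the scatter, a 1.3-fold lower number from compound 1 to compound 4 (0.13 log units; within the scatter).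

The compounds shown leave open whether a bromo or methyl group on that aromatic carbon would behave as chloro does. They also leave open how a benzylamino or phenoxy group on the carbonyl carbon would compare with the arylamino group.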